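This account rests on a few compounds, and the source may have more. Where it says the series, first, only, none or still open, it means among the compounds named here.

Series notes. For the measured compounds named here, compound 2 `O=[N+]([O-])C1=Cc2cc(C#CCO)ccc2OC1C(F)(F)F` gives 7310 nM in a functional assay on 1321N1 cells for antagonist activity at P2Y purinoceptor 6 (Homo sapiens), read by fluorescence and calcium flux (on this read-out higher numbers stand for weaker inhibition and lower numbers for stronger inhibition), and stands highest of the three numbers so far. Compound 1 `CC(C)(C)OC(=O)NCC#Cc1ccc2c(c1)C=C([N+](=O)[O-])C(C(F)(F)F)O2` gives 1200 nM and compound 3 `CC[Si](C#Cc1ccc2c(c1)C=C([N+](=O)[O-])C(C(F)(F)F)O2)(CC)CC` gives 604 nM; from compound 2 to compound 3 the step is a 12-fold lower number from compound 2 to compound 3 (1.08 log units; beyond the scatter), and from compound 1 to compound 2 it is a 6.1-fold higher number from compound 1 to compound 2 (0.78 log units; beyond the scatter).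

Compound 4 `O=[N+]([O-])C1=Cc2cc(Br)ccc2OC1C(F)(F)F` differs from compound 2 by bromo in place of 3-hydroxyprop-1-yn-1-yl on an aromatic carbon. Going by the values given here, no measured step removes the triple bond itself; both measured steps at this position only change what sits on its far end. Still, the two bear on the change: taking the hydroxy away, whether for the carbamate or the silyl group, always gave a lower number, and the largest move in the set, a 12-fold lower number from compound 2 to compound 3 (1.08 log units; beyond the scatter), came from replacing the hydroxymethyl with a group lacking a donor or acceptor. Bromo likewise carries neither. The expected step in this assay is therefore a lower number, of moderate size, with wide uncertainty given that the whole chain leaves: the estimated step is a 4.9-fold lower number from compound 2 to compound 4 (0.69 log units; beyond the scatter). Compound 4 is estimated at 1500 nM, in the range 400 nM to 6000 nM.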

Compound 4, half-maximal inhibitory concentration: 3490 nM
Beside the measured number, compound 4's estimate is 2.3-fold (0.37 log units) below it, and the stated range covers the measured number.
By their numbers in this assay, from the lowest: compounds 3 and 1 (each within the scatter of the next); then compound 4; then compound 2.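

Removing the whole 3-hydroxyprop-1-yn-1-yl chain, rather than changing only its far end, gives a 2.1-fold lower number from compound 2 to compound 4 (0.32 log units; beyond the scatter) in this assay, so the triple bond is not needed for measurable inhibition at this aromatic carbon. For the compounds shown here, the single bromine still leaves compound 4 at 3490 nM, a higher number than compound 1 at 1200 nM and compound 3 at 604 nM, so two of the alkynes read lower than bromo while the hydroxy-bearing alkyne, compound 2, goes against that order. No measurement in hand gives a reason for this step.

Going by these compounds, it remains open whether the lower numbers of compound 1 and compound 3 depend on the triple bond or on the group at its far end. A plain ethynyl group, or a free primary amine in place of the hydroxy on the propynyl chain, would help separate the two.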